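Acetamido in place of trifluoromethyl on compound 2

The compounds below may be only part of what the source reports. "The series", "measured", "known", "first", "only" and "open" are said of these compounds alone.

In an ADME assay on L02 cells (Homo sapiens) for cytotoxicity, read by MTT assay, with a stated time of 24 h (a higher number here means a weaker inhibitor, a lower number a stronger inhibitor), compound 1 `O=C1/C(=C/c2cccnc2)CN(S(=O)(=O)c2ccc(C(F)(F)F)cc2)C/C1=C\c1ccccc1F` gives 11300 nM and compound 2 `O=C1/C(=C/c2ccncc2)CN(S(=O)(=O)c2ccc(C(F)(F)F)cc2)C/C1=C\c1ccccc1F` gives 18600 nM and so stands within the scatter of compound 1. Compound 3 `CC(=O)Nc1ccc(S(=O)(=O)N2C/C(=C\c3ccncc3)C(=O)/C(=C/c3ccccc3F)C2)cc1` differs from compound 2 by acetamido in place of trifluoromethyl on an aromatic carbon. Within the data shown here, the only measured step (a 1.6-fold higher number from compound 1 to compound 2 (0.22 log units; within the scatter)) puts pyridin-4-yl in place of pyridin-3-yl, stays within the scatter and offers no direct guide to this change. No shift beyond the scatter is therefore expected, an estimated 1.0-fold lower number from compound 2 to compound 3 (0.01 log units; within the scatter) with wide uncertainty. For compound 3 the estimated value is 18000 nM (expected range 7000 nM to 45000 nM).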

Compound 3, half-maximal inhibitory concentration: 12300 nM
Compound 3: middle estimate off by 1.5-fold (0.17 log units), on the high side, and the stated range covers the measured number.
By their numbers in this assay, from the lowest: compounds 1, 3 and 2 (each within the scatter of the next).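

In this assay, acetamido in place of trifluoromethyl on this aromatic carbon, para to a large group, gives a 1.5-fold lower number from compound 2 to compound 3 (0.18 log units; within the scatter) and so marks the first change shown at this position. A group with a hydrogen-bond donor and acceptor, which trifluoromethyl lacks, is thus carried here without a shift beyond the scatter. Nothing measured here accounts for this result. The compounds leave open whether an amine, a carboxylic acid or a longer chain at this position would also stay within the scatter. They also leave open whether acetamido would do the same alongside the pyridin-3-yl group of compound 1.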